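A Fluorophenyl Swap on a Triazole Sulfonamide Series

The compounds below may be only part of what the source reports. "The series", "measured", "known", "first", "only" and "open" are said of these compounds alone.

Among the compounds with values here, compound 2 `Cc1ccc(-n2cc(-c3ccccc3NS(=O)(=O)c3c[nH]c(=O)[nH]c3=O)nn2)cc1` is one of two compounds measured so far in a functional assay on HepG2 cells (Homo sapiens) for antiproliferative activity, read by MTT assay, with a stated time of 24 h; on this read-out lower numbers stand for stronger inhibition and higher numbers for weaker inhibition. In this assay compound 2 gives 8350 nM, while compound 1 `O=c1[nH]cc(S(=O)(=O)Nc2ccccc2-c2cn(-c3ccccc3)nn2)c(=O)[nH]1` gives 6160 nM. Within the data shown here, the only measured step, a 1.4-fold higher number from compound 1 to compound 2 (0.13 log units; within the scatter), arises from a methyl in place of hydrogen on an aromatic carbon, so the two numbers sit within the scatter of each other and neither compound can be set above the other.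

Compound 3 `O=c1[nH]cc(S(=O)(=O)Nc2ccccc2-c2cn(-c3ccccc3F)nn2)c(=O)[nH]1` has not yet been measured in this assay. It differs from compound 2 by 2-fluorophenyl in place of 4-methylphenyl on an aromatic nitrogen. Among the measured compounds shown here, no measured step covers this particular exchange; the one step at hand, a 1.4-fold higher number from compound 1 to compound 2 (0.13 log units; within the scatter), concerns only the methyl group and did not move the number beyond the scatter, and nothing measured speaks to the fluorine. For the measured compounds named here, since the single piece of evidence shows that altering this phenyl left the read-out unchanged, the expected step from compound 2 to compound 3 is a 1.2-fold lower number from compound 2 to compound 3 (0.08 log units; within the scatter), none beyond the scatter. Compound 3 is therefore estimated at 7000 nM in this assay, with a likely range from 3000 nM to 16000 nM.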

Compound 3, half-maximal inhibitory concentration: 12500 nM
Beside the measured number, compound 3's estimate is 1.8-fold (0.25 log units) below it; measured number inside the range.
By their numbers in this assay, from the lowest: compounds 1, 2 and 3 (each within the scatter of the next, the first and the last beyond it).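

In this assay the exchange of 4-methylphenyl for 2-fluorophenyl on the aromatic nitrogen gives (a 1.5-fold higher number from compound 2 to compound 3 (0.18 log units; within the scatter)), so this pair cannot be told apart, even though the two groups differ in what they carry on the phenyl ring. The comparison with the unsubstituted phenyl of compound 1 is more informative: adding a fluoro group to this phenyl gives (a 2.0-fold higher number from compound 1 to compound 3 (0.31 log units; beyond the scatter)), a modest step and the first at this position to pass the scatter, whereas the methyl step (a 1.4-fold higher number from compound 1 to compound 2 (0.13 log units; within the scatter)) did not, so a single small substituent on this phenyl can move the number towards weaker inhibition, if only just. Nothing available here bears on what lies behind this shift.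

The compounds shown leave open whether the shift grows, fades or reverses with other groups on this phenyl, such as a methoxy group, an amine or a carboxylic acid. They also leave open whether replacing the phenyl itself with a saturated ring such as cyclohexyl, or with a short alkyl chain such as butyl, would change the number beyond the scatter.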